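A ring gives way to an open chain on the shared core

A few compounds are considered here, and "the series" means these few. Any claim that something is new, unique, unknown or untested is made for them only; others in the source may bear on it.

Among the measured compounds shown here, in a functional assay for activation of Alpha-1D adrenergic receptor (Homo sapiens) (a lower number here means that less compound is needed, a higher number that more compound is needed for the effect), compound 3 `c1ccc(-c2ccccc2NCC2=NCCN2)nc1` gives 41.7 nM, the only full number among the three compounds measured. For compound 1 `Cc1nc(-c2ccccc2NCC2=NCCN2)no1` the reading is a limit of the assay, < 5020 nM. For compound 2 `Cc1ccc(-c2ccccc2NCC2=NCCN2)o1` the reading is likewise a limit of the assay, < 2000 nM. The unmeasured compound 4 `CO/N=C/c1ccccc1NCC1=NCCN1` differs from compound 3 in one place: a group of 4 heavy atoms (2 carbon, 1 nitrogen, 1 oxygen; no ring) in place of a group of 6 heavy atoms (5 carbon, 1 nitrogen; one six-membered aromatic ring with 1 hetero atom), on an aromatic carbon. Three measured steps exchange groups on that same aromatic carbon of the shared core, yet none of them yields a size: a step that the limit leaves unreadable from compound 1 to compound 3, a step that the limit leaves unreadable from compound 2 to compound 3 and a step that the two limits leave unreadable from compound 1 to compound 2. The limits the limit of < 2000 nM in this assay, at which 1 of the 3 values shown sits, and the limit of < 5020 nM in this assay, at which 1 of the 3 values shown sits, leave all three unreadable. For the measured compounds named here, every group in those steps carries a ring, while the group entering compound 4 has none, so no measured step speaks directly to this change, and neither its direction nor its size can be read from the numbers in hand. The estimate for compound 4 in this assay is 200 nM, expected to fall between 30 nM and 1500 nM. Going by these compounds, this amounts to an expected step of a 4.8-fold higher number from compound 3 to compound 4 (0.68 log units; beyond the scatter) whose direction remains open.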

Compound 4, half-maximal effective concentration: < 5020 nM
Compound 4 was reported as a limit; the forecaster's own chance of this, stated with the estimate: 15%; the middle value lies beyond the limit too.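

In this assay compound 4 gives only a limit of the assay, < 5020 nM. None of its steps from compound 1, compound 2 or compound 3 can be read. Going by these compounds, how the open chain of compound 4 compares with the pyridin-2-yl group of compound 3 remains open, in both direction and size.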